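The source may report more compounds than this note shows. Statements on the series, on what has been measured and on what is new or still open speak of the compounds shown alone.

Measured compounds and their numbers:

Compound 1 `N#Cc1ccccc1-c1cnc(C(=O)CCCCCCc2ccccc2)o1` gives 130 nM in an assay (Rattus norvegicus) for inhibition of Fatty-acid amide hydrolase 1 (Homo sapiens); on this read-out lower numbers stand for stronger inhibition and higher numbers for weaker inhibition.
Compound 2 `COC(=O)c1ccc(-c2cnc(C(=O)CCCCCCc3ccccc3)o2)cc1` gives 40 nM in this assay.
Compound 3 `O=C(CCCCCCc1ccccc1)c1ncc(-c2ccc(C(=O)C(F)(F)F)cc2)o1` gives 65 nM in this assay.

Compound 3 stands second highest of the three numbers; its nearest neighbour is compound 2, and compound 1 lies furthest from it, both within the scatter. Compound 4 `N#Cc1ccc(-c2cnc(C(=O)CCCCCCc3ccccc3)o2)cc1` is the unmeasured member of the group; it differs from compound 3 by cyano in place of (trifluoromethyl)carbonyl on an aromatic carbon. Within the data shown here, the one measured step that bears on this change is the exchange of groups at the same place, a 1.6-fold higher number from compound 2 to compound 3 (0.21 log units; within the scatter), which stayed within the scatter. The group entering in compound 4 is the same cyano that compound 1 carries at a different place, and compound 1 and compound 3 also lie within the scatter of each other. On this basis no step beyond the scatter is expected from compound 3 to compound 4, with an estimated step of a 1.1-fold lower number from compound 3 to compound 4 (0.03 log units; within the scatter). Compound 4 is therefore expected to give about 60 nM in this assay, within a range from 25 nM to 150 nM.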

Compound 4, inhibition constant: 40 nM
Compound 4: middle estimate off by 1.5-fold (0.18 log units), on the high side; measured number inside the range.
By their numbers in this assay, from the lowest: compounds 2, 4, 3 and 1 (each within the scatter of the next, the first and the last beyond it).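

In this assay, among these compounds, the change from 2-cyanophenyl to 4-cyanophenyl gives a 3.3-fold lower number from compound 1 to compound 4 (0.51 log units; beyond the scatter), so the place of the cyano on the six-membered aromatic ring matters, and this is the one step here that passes the scatter. At the place para to a large group, the size of the group does not separate the compounds: a cyano of 2 heavy atoms replacing a (trifluoromethyl)carbonyl of 6 heavy atoms gives a 1.6-fold lower number from compound 3 to compound 4 (0.21 log units; within the scatter), and cyano in place of methoxycarbonyl gives no change at the digits printed from compound 2 to compound 4 (within the scatter), both within the scatter. No measurement offered here accounts for either result.

The compounds shown leave open whether a carboxylic acid or an amine on that aromatic carbon would stay within the scatter of compound 4, and whether moving methoxycarbonyl around the ring would repeat the step seen with cyano. They also leave open how a longer chain on the carbonyl would act alongside the 4-cyanophenyl group.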